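Removing a Ring Methyl Where Both Analogues Hit the Limit

This account rests on a few compounds, and the source may have more. Where it says the series, first, only, none or still open, it means among the compounds named here.

Compound 1 `CCCc1nc(C)c2cnn(CC)c(=O)n12`: > 48000 nM, a limit rather than a number.
Compound 2 `CCCc1nc(C)c2c(C)nn(CC(=O)OCC)c(=O)n12`: > 48000 nM, likewise a limit rather than a number.

In a functional assay for inhibition, with Homo sapiens as the target (a lower number here means a stronger inhibitor, a higher number a weaker inhibitor), compound 2 gives > 48000 nM, which is a limit and not a measured value. Within the data shown here, compound 1 also reaches only a limit in this assay, at > 48000 nM. the limit of > 48000 nM in this assay, at which 2 of the 2 values shown sit, marks the point where both values sit, so no step between measured compounds exists and nothing is known about how any single change moves the read-out.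

Compound 3 `CCCc1nc(C)c2cnn(CC(=O)OCC)c(=O)n12` differs from compound 2 by hydrogen in place of methyl on an aromatic carbon. Compound 1 also carries hydrogen at such a carbon and sits at its limit of > 48000 nM. The step that the limit leaves unreadable from compound 2 to compound 3 is therefore expected to be none beyond the scatter, with the value staying at the limit. Compound 3 is estimated at 60000 nM, with a range from 20000 nM to 200000 nM, and most likely only a limit will again be recorded.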

Compound 3, half-maximal inhibitory concentration: > 48000 nM
Compound 3: only a limit was reported; the forecaster's own chance of this, stated with the estimate: 85%; the middle value lies beyond the limit too.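

Among these compounds, compound 3 also gives only a limit in this assay, so no step from compound 1 or compound 2 to compound 3 can be read: the limit of > 48000 nM in this assay, at which 3 of the 3 values shown sit. The compounds shown leave open whether any change to the shared core moves the read-out to a measurable value.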